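Swapping the aryl cap for a pyridine on the alkyne

The source may report more compounds than this note shows. Statements on the series, on what has been measured and on what is new or still open speak of the compounds shown alone.

Measured compounds:
- compound 1, `Cc1cccc(C#Cc2ccc3c(n2)CCN(C)C3=O)c1`, 2.9 nM
- compound 2, `CN1CCc2nc(C#Cc3cccnc3)ccc2C1=O`, "not active" (no number reported)
- compound 3, `Cc1cccc(C#Cc2ccc3c(n2)CCN(C(C)C)C3=O)c1`, 4.8 nM

Compound 3 was tested in a functional assay on HEK293 cells for negative allosteric modulation of metabotropic glutamate receptor 5 (Homo sapiens), read by FLIPR and calcium flux (a higher number here means a weaker inhibitor, a lower number a stronger inhibitor), and gave 4.8 nM. Among the two compounds with a number, compound 3 has the higher one; the single step on record, a 1.7-fold higher number from compound 1 to compound 3 (0.22 log units; within the scatter), lies within the scatter, so compound 1 and compound 3 cannot be told apart. Compound 2 carries the pyridin-3-yl cap with a methyl on the amide-type nitrogen and was reported as not active in this assay.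

Compound 4, `CC(C)N1CCc2nc(C#Cc3cccnc3)ccc2C1=O`, keeps the isopropyl of compound 3 and differs only at the cap: pyridin-3-yl in place of 3-methylphenyl on a triple-bonded carbon. For the measured compounds named here, no step in this set directly covers that swap on the isopropyl series. Going by the values given here, the only guidance is compound 2, whose pyridin-3-yl cap came with no measurable activity, so a large weakening is expected: a 2100-fold higher number from compound 3 to compound 4 (3.32 log units; beyond the scatter). Compound 4 is therefore estimated at 10000 nM, within 2000 nM to 50000 nM, with a real chance that only inactivity is reported.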

Compound 4, half-maximal inhibitory concentration: "not active" (no number reported)
Compound 4: no number reported, and the estimate cannot be compared.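

For the compounds shown here, compound 4, like compound 2, was reported as not active in this assay with no number, so no step from compound 3 to compound 4 can be read. No measured evidence shown bears on this result. The compounds shown leave open what number, if any, a pyridin-3-yl cap would give against the 3-methylphenyl cap of compound 3.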